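Aryl replacement at the shared core: indolyl to fluoromethoxyphenyl

A few compounds are considered here, and "the series" means these few. Any claim that something is new, unique, unknown or untested is made for them only; others in the source may bear on it.

Compound 1 `COc1cc(-c2ccnc3cc(-c4ccc5cc[nH]c5c4)nn23)cc(OC)c1OC` gives 187 nM in a functional assay on HCT-116 cells (Homo sapiens) for inhibition, read by CCK-8 assay, with a stated time of 48 h (a higher number here means a weaker inhibitor, a lower number a stronger inhibitor), and holds the lowest of the two numbers shown. Compound 2 `COc1cc(-c2ccnc3cc(-c4cccc5c4ccn5CO)nn23)cc(OC)c1OC` gives 861 nM in this assay, a gap beyond the scatter. Compound 3 `CCOC(=O)c1ccc(-c2cc3nccc(-c4cc(OC)c(OC)c(OC)c4)n3n2)cc1` returns only a limit, > 10000 nM, in this assay; this is the limit of > 10000 nM in this assay, at which 1 of the 3 values shown sits.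

Compound 4 `COc1ccc(-c2cc3nccc(-c4cc(OC)c(OC)c(OC)c4)n3n2)cc1F` differs from compound 1 at one position: 3-fluoro-4-methoxyphenyl in place of 1H-indol-6-yl on an aromatic carbon. Among the measured compounds shown here, no step between measured compounds matches this change. The two measured carriers of a six-membered aromatic ring alone in this place, compound 2 and compound 3, sit above compound 1, so a step toward a higher number in this assay is expected, beyond the scatter. Compound 4 is estimated at 1500 nM, within 300 nM to 8000 nM, a step of an 8.0-fold higher number from compound 1 to compound 4 (0.90 log units; beyond the scatter) expected from compound 1.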

Compound 4, half-maximal inhibitory concentration: 2840 nM
For compound 4 the middle estimate is 1.9-fold (0.28 log units) below the measured one, within the range that was stated.
By their numbers in this assay, from the lowest: compound 1; then compound 2; then compound 4. At a limit, above all of these: compound 3.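

Among the compounds shown here, at this position on the shared core, the first single-place comparison gives a large step in this assay: a 15-fold higher number from compound 1 to compound 4 (1.18 log units; beyond the scatter) with 3-fluoro-4-methoxyphenyl in place of 1H-indol-6-yl. The position is therefore sensitive to this aryl exchange, even though the two groups have the same heavy-atom count. Nothing shown gives a cause for this step.

The change removes the five-membered aromatic ring and the hydrogen-bond donor together, so their shares remain unseparated. An indole with a methyl on its ring nitrogen, or an aminophenyl, would bear on this.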